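Swapping 4-chlorophenyl for pyridin-2-yl on the shared core

The source may hold more compounds than are shown below. What is called first, only, known or untested is meant among the compounds shown, and "the series" means these compounds.

Of the compounds shown here, three with a shared core have been measured in an ADME assay on Vero cells (Chlorocebus sabaeus) for cytotoxicity, read by MTT assay, with a stated time of 72 h; on this read-out lower numbers stand for higher toxicity in this test and higher numbers for lower toxicity in this test. Compound 1 `CN(C)c1ccc(/C=C/C(=O)c2ccc3c(c2O)C=CC(C)(C)O3)cc1` reports > 400000 nM, which is a limit of the assay and not a number. Compound 2 `CC(=O)Nc1ccc(/C=C/C(=O)c2ccc3c(c2O)C=CC(C)(C)O3)cc1` gives 279000 nM. For the measured compounds named here, compound 3 `CC1(C)C=Cc2c(ccc(C(=O)/C=C/c3ccc(Cl)cc3)c2O)O1` gives 92200 nM, the lowest number so far, and its nearest numerical neighbour is compound 2.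

The next compound to be measured is compound 4 `CC1(C)C=Cc2c(ccc(C(=O)/C=C/c3ccccn3)c2O)O1`. Its difference from compound 3 is pyridin-2-yl in place of 4-chlorophenyl on a double-bonded chain carbon bound to a double-bonded chain carbon, with pyridin-2-yl in place of 4-chlorophenyl on a double-bonded chain carbon bound to a double-bonded chain carbon.

Going by the values given here, no measured step makes this exact exchange, so the closest guidance comes from the steps that change the group on the aromatic ring. Introducing chloro gave a 3.0-fold lower number from compound 2 to compound 3 (0.48 log units; beyond the scatter), and it also gave an at least 4.3-fold lower number from compound 1 to compound 3 (0.63 log units; beyond the scatter). The remaining step, an at least 1.4-fold lower number from compound 1 to compound 2 (0.15 log units; that floor lies within the scatter), has a floor within the scatter and says little. Compound 4 gives up the chloro group that marks the lowest number, so the measured steps point upward in this assay, and a modest change is expected, with the estimated step being a 2.2-fold higher number from compound 3 to compound 4 (0.34 log units; beyond the scatter). For compound 4 the estimated value is 200000 nM. The expected range runs from 70000 nM to 400000 nM.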

Compound 4, half-maximal cytotoxic concentration: 20500 nM
Compound 4: middle estimate off by 9.8-fold (0.99 log units), on the high side; the measured number lies below the stated range.
By their numbers in this assay, from the lowest: compound 4; then compound 3; then compound 2. At a limit, above all of these: compound 1.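

In this assay the exchange of the whole aromatic ring on the double-bonded chain carbon brings a 4.5-fold lower number from compound 3 to compound 4 (0.65 log units; beyond the scatter) and so moves the number downward, not upward as the loss of chloro had seemed to imply. For the compounds shown here, the chlorine is therefore not needed for a low number at this place: compound 4 has no chlorine, carries a ring nitrogen and a hydrogen-bond acceptor instead, and now holds the lowest number of the series, whereas the earlier steps had changed only the group on a phenyl ring and never the ring itself. The compounds shown offer no measured basis for a cause of this step.

They leave open whether the drop belongs to the loss of the chlorine or to the entry of the ring nitrogen, a question that a plain phenyl group at this place would separate. They also leave open whether the place of the nitrogen within the ring matters, which pyridin-3-yl and pyridin-4-yl would test against pyridin-2-yl.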